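The compounds below may be only part of what the source reports. "The series", "measured", "known", "first", "only" and "open" are said of these compounds alone.

Compound 1 `COCOc1ccc(CN(Cc2ccc(C(C)(C)C)cc2)Cc2cc3cc(C)ccc3[nH]c2=O)cc1` is the reference point of this small series. In a toxicity assay on MDCK cells (Canis lupus familiaris) for cytotoxicity, read by crystal violet staining, with a stated time of 48 h (a lower number here means that less compound is tolerated, a higher number that more compound is tolerated), compound 1 gives 6400 nM. Compound 2 `CCc1ccc2[nH]c(=O)c(CN(Cc3ccc(OCOC)cc3)Cc3ccc(C(C)(C)C)cc3)cc2c1` carries methyl in place of hydrogen on a saturated chain carbon bound to an aromatic carbon. In this assay compound 2 reaches only the limit of the measurement, > 10000 nM. The step of an at least 1.5-fold higher number from compound 1 to compound 2 (0.19 log units; that floor lies within the scatter) can therefore be given only as a floor, and that floor is tied to the limit of > 10000 nM in this assay, at which 2 of the 3 values shown sit.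

Compound 3 `Cc1ccc2[nH]c(=O)c(CN(Cc3ccc(C(C)(C)C)cc3)[C@H](CO)c3ccccc3)cc2c1` shares the core of compound 1 but differs at the amine nitrogen by 2-hydroxy-1-phenylethyl in place of 4-(methoxymethoxy)benzyl on an amine nitrogen. In this assay compound 3 likewise sits at the limit, > 10000 nM. The step of an at least 1.5-fold higher number from compound 1 to compound 3 (0.19 log units; that floor lies within the scatter) is again only a floor, resting on (the limit of > 10000 nM in this assay, at which 2 of the 3 values shown sit).

Compound 4 `CCc1ccc2[nH]c(=O)c(CN(Cc3ccc(C(C)(C)C)cc3)[C@H](CO)c3ccccc3)cc2c1` has not yet been measured. It is made from compound 3 by methyl in place of hydrogen on a saturated chain carbon bound to an aromatic carbon, which is the same change as that from compound 1 to compound 2, since the place is the same in both pairs: a saturated chain carbon bound to an aromatic carbon. The step is expected to be about a step that the limit leaves unreadable from compound 3 to compound 4, that is, compound 4 is expected to remain at or beyond the limit. That expectation rests on compound 3, whose value in this assay is the limit > 10000 nM. It also rests on the earlier step of an at least 1.5-fold higher number from compound 1 to compound 2 (0.19 log units; that floor lies within the scatter), which gave no sign of a lower number. Compound 4 is thus estimated at 15000 nM, within the range from 7000 nM to 40000 nM, most likely reported only as a limit.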

Compound 4, half-maximal cytotoxic concentration: > 10000 nM
Compound 4 gave a limit, no number; the forecaster's own chance of this, stated with the estimate: 80%; the middle value is on the limit's open side.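

In this assay compound 4 ends at a limit, as compound 3 and compound 2 do, so neither the step from compound 3 nor the step from compound 2 can be read: the limit of > 10000 nM in this assay, at which 3 of the 4 values shown sit.

The compounds shown leave open where the half-maximal cytotoxic concentrations of compound 2, compound 3 and compound 4 actually lie, and whether methyl in place of hydrogen at this place changes the read-out at all.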